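A few compounds are considered here, and "the series" means these few. Any claim that something is new, unique, unknown or untested is made for them only; others in the source may bear on it.

Measured so far:
compound 1 `CCOC(=O)Nc1sc(-c2ccc(Cl)cc2)c(-c2ccc(Cl)cc2)c1C(=O)NC1CC1`: 27600 nM
compound 2 `Nc1sc(-c2ccc(Cl)cc2)c(-c2ccc(Cl)cc2)c1C(=O)N1CCNCC1`: 2710 nM

In a functional assay on PC-3 cells (Homo sapiens) for inhibition, read by sulforhodamine B assay, with a stated time of 72 h (on this read-out higher numbers stand for weaker inhibition and lower numbers for stronger inhibition), compound 2 gives the lowest of the two numbers; compound 1 stands well above it, beyond the scatter. For the measured compounds named here, no step between compounds differing in a single place is available. Compound 3 `Nc1sc(-c2ccc(Cl)cc2)c(-c2ccc(Cl)cc2)c1C(=O)NC1CC1` awaits measurement; against compound 2 it shows (cyclopropylamino in place of piperazin-1-yl on a carbonyl carbon). Compound 3 carries the cyclopropylamino group of compound 1, which gives 27600 nM, together with the free amine of compound 2, so a moderate move up from compound 2 is expected a 3.0-fold higher number from compound 2 to compound 3 (0.47 log units; beyond the scatter). Compound 3 is estimated at 8000 nM, within 2500 nM to 30000 nM.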

Compound 3, half-maximal inhibitory concentration: 3680 nM
Compound 3: the middle estimate sits 2.2-fold (0.34 log units) above what was measured, within the range that was stated.
By their numbers in this assay, from the lowest: compounds 2 and 3 (each within the scatter of the next); then compound 1.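

In this assay the carbonyl carbon accepts the exchange of piperazin-1-yl for cyclopropylamino with no readable change, giving a 1.4-fold higher number from compound 2 to compound 3 (0.13 log units; within the scatter) as the step. With cyclopropylamino held fixed, the nitrogen on an aromatic ring shows the clearer effect, since hydrogen in place of ethoxycarbonyl gives a 7.5-fold lower number from compound 1 to compound 3 (0.88 log units; beyond the scatter) and this lies beyond the scatter. No measured evidence accounts for either step. On these data alone, whether an acetyl or methyl group on that nitrogen reads like ethoxycarbonyl or like hydrogen remains open. So does the reading of morpholin-4-yl or dimethylamino on the carbonyl carbon.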